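The compounds below may be only part of what the source reports. "The series", "measured", "known", "first", "only" and "open" are said of these compounds alone.

Of the compounds shown here, three with a shared core have been measured in an assay on isolated protein for binding affinity to leukotriene B4 receptor 1 (Homo sapiens), tested at 1 uM; on this read-out lower numbers stand for less inhibition and higher numbers for more inhibition at the one concentration tested (going by the name of the read-out). Compound 1 `CC(=O)c1cc(CC(C)O)c(OCCCCC#N)cc1O` gives 6% in this assay. Compound 3 `C=CCCCCOc1cc(O)c(C(C)=O)cc1CC=C` gives 27%. Compound 2 `CCc1cc(C(C)=O)c(O)cc1OCCCC(C)(C)C#N` gives 46%, the highest of the three numbers; its nearest neighbour is compound 3, a number below it beyond the usual scatter, and the furthest is compound 1, a number further below it, also beyond the scatter.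

The next compound, compound 4 `CCc1cc(C(C)=O)c(O)cc1OCCCCCCC(=O)O`, has not yet been measured in this assay. It differs from compound 2 in a single place: 3-carboxypropyl in place of 1-cyano-1-methylethyl on a saturated chain carbon, three bonds along the chain from an oxygen on an aromatic ring. Going by the values given here, no step between two measured compounds shows this kind of change, so the effect on this assay is open.

The expectation for compound 4 is an upward step from compound 2 beyond the scatter, a number 14 percentage points higher from compound 2 to compound 4 (beyond the scatter). Compound 4 is accordingly estimated to give 60% in this assay, within a range from 30% to 85%.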

Compound 4, a percentage reported as inhibition, at one concentration (the size of the read-out at that concentration, not a potency): 38%
Compound 4: middle estimate off by 22 percentage points, on the high side, within the range that was stated.
By their numbers in this assay, from the lowest: compound 1; then compound 3; then compounds 4 and 2 (each within the scatter of the next).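

Putting 3-carboxypropyl in place of 1-cyano-1-methylethyl, on a saturated chain carbon three bonds along the chain from an oxygen on an aromatic ring, gives a number 8 percentage points lower from compound 2 to compound 4 (within the scatter) in this assay. Going by these compounds alone, this is the first step between compounds that differ in one place, and it shows that this chain end can change from a branched nitrile to an unbranched carboxylic acid without a shift that stands clear of the scatter. Nothing measured bears on why the two compounds read alike.

The compounds shown leave open whether the end group or the chain length matters more at this position. A methyl ester or an amine on the same chain, or a carboxylic acid on a shorter chain, would help separate the two.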